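Sulfonamide to amide exchange in the trimethoxyphenyl benzimidazole series

This account rests on a few compounds, and the source may have more. Where it says the series, first, only, none or still open, it means among the compounds named here.

Compound 1 `COc1ccc(CN(c2cc(OC)c(OC)c(OC)c2)S(=O)(=O)c2ccccc2)cc1` — > 50000 nM
Compound 2 `COc1cc(N(Cc2nc3ccccc3[nH]2)S(=O)(=O)c2ccccc2)cc(OC)c1OC` — 12400 nM
Compound 3 `Cc1ccc(S(=O)(=O)N(Cc2nc3ccccc3[nH]2)c2ccccc2)cc1` — 45200 nM

In a functional assay on MGC-803 cells (Homo sapiens) for inhibition, read by MTT assay, with a stated time of 48 h (a higher number here means a weaker inhibitor, a lower number a stronger inhibitor), compound 2 shows the lowest number of the two numbers shown. For compound 1 the value is a limit of the assay, not a number (the limit of > 50000 nM in this assay, at which 1 of the 3 values shown sits). Compound 3 sits above compound 2 in this assay. Going by the values given here, the one measured step, an at least 4.0-fold lower number from compound 1 to compound 2 (0.60 log units; beyond the scatter), concerns a different position and does not touch the sulfonyl group. Compound 4 `COc1cc(N(Cc2nc3ccccc3[nH]2)C(=O)c2ccccc2)cc(OC)c1OC` carries benzoyl in place of phenylsulfonyl on a nitrogen on an aromatic ring. Among the compounds with values here, no measured pair covers this change, so the step from compound 2 to compound 4 is expected to stay near the scatter, with a modest shift in either direction possible; the expected step is a 1.0-fold lower number from compound 2 to compound 4 (0.01 log units; within the scatter). Compound 4 is estimated at 12000 nM, between 3000 nM and 45000 nM.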

Compound 4, half-maximal inhibitory concentration: > 50000 nM
Compound 4: a limit, no number; the forecaster's own chance of this, stated with the estimate: 15%; middle value at least 4.1-fold (0.61 log units) from the limit.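

Benzoyl in place of phenylsulfonyl on a nitrogen on an aromatic ring gives an at least 4.0-fold higher number from compound 2 to compound 4 (0.60 log units; beyond the scatter) in this assay, so the activity of compound 2 depends on its phenylsulfonyl group. The earlier compounds shown here all keep a sulfonyl group and could not show this. For compound 4 the result is a limit of the assay, not a number: the limit of > 50000 nM in this assay, at which 2 of the 4 values shown sit.

From the compounds shown here alone, the size of the step therefore stays open. So does how a methylsulfonyl or 4-aminophenylsulfonyl group would read on this nitrogen.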